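Cyclobutyl for Cyclopropyl on a Sulfonamide Nitrogen

This account rests on a few compounds, and the source may have more. Where it says the series, first, only, none or still open, it means among the compounds named here.

Of the compounds shown here, three have been measured in a functional assay on BXPC-3 cells (Homo sapiens) for inhibition, read by MTT assay, with a stated time of 7 days; on this read-out higher numbers stand for weaker inhibition and lower numbers for stronger inhibition. Compound 1 `CCOC(=O)C1CCN(S(=O)(=O)c2ccc(S(=O)(=O)N(CC)CC)cc2)CC1` gives 23100 nM, compound 2 `CCN(CC)S(=O)(=O)c1ccc(S(=O)(=O)N2CCC[C@@H](C(=O)NC3CN(C(=O)NC(C)(C)C)C3)C2)cc1` gives 10100 nM, and compound 3 `CC(C)c1noc(N2CCN(C(=O)[C@@H]3CCCN(S(=O)(=O)c4ccc(S(=O)(=O)NC5CC5)cc4)C3)CC2)n1` gives 6700 nM. Compound 3 thus stands at the lowest of the three numbers; its nearest neighbour is compound 2, whose number lies within the scatter of its own, while compound 1 lies beyond the scatter. Compound 4 `CC(C)c1noc(N2CCN(C(=O)[C@@H]3CCCN(S(=O)(=O)c4ccc(S(=O)(=O)NC5CCC5)cc4)C3)CC2)n1` has not yet been measured in this assay. It differs from compound 3 in one place: cyclobutyl in place of cyclopropyl on a sulfonamide nitrogen. Among the measured compounds shown here, no pair of measured compounds shows this change, so the step is expected to stay within the scatter, with no clear direction, a 1.0-fold lower number from compound 3 to compound 4 (0.01 log units; within the scatter). Compound 4 is therefore estimated at 6500 nM, in a range from 3000 nM to 14000 nM.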

Compound 4, half-maximal inhibitory concentration: 3300 nM
The estimate for compound 4 lay 2.0-fold (0.29 log units) above the measured number; measured number inside the range.
By their numbers in this assay, from the lowest: compound 4; then compounds 3 and 2 (each within the scatter of the next); then compound 1.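

Cyclobutyl in place of cyclopropyl on a sulfonamide nitrogen gives a 2.0-fold lower number from compound 3 to compound 4 (0.31 log units; beyond the scatter) in this assay. Among the compounds shown here, the step is modest, but it is the first single-place comparison, and it shows that this position responds to a change of one ring carbon. No measurement at hand explains the step.

The compounds shown leave open whether a cyclopentyl ring on this nitrogen would extend the step in the same direction. They also leave open how an open chain such as isopropyl or a ring bearing an amine would compare.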